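Adding a Bromo Group to the Benzyl Ring

The compounds below may be only part of what the source reports. "The series", "measured", "known", "first", "only" and "open" are said of these compounds alone.

Compound 3 `O=S(=O)(NCCCNCc1ccccc1)c1cc(C(F)(F)F)cc(C(F)(F)F)c1` is the plain benzyl member of this small set. In a functional assay on Capan-2 cells (Homo sapiens) for inhibition, read by MTT assay, with a stated time of 72 h (on this read-out lower numbers stand for stronger inhibition of growth and higher numbers for weaker inhibition of growth), compound 3 gives 14000 nM, the second highest of the three numbers measured. Compound 2 `COc1ccc(CNCCCNS(=O)(=O)c2cc(C(F)(F)F)cc(C(F)(F)F)c2)cc1OC` gives 15000 nM, and a 1.1-fold lower number from compound 2 to compound 3 (0.03 log units; within the scatter), so these two cannot be told apart. Compound 1 `O=S(=O)(NCCCNCc1ccc(Cl)c(Cl)c1)c1cc(C(F)(F)F)cc(C(F)(F)F)c1` gives 1800 nM, and a 7.8-fold higher number from compound 1 to compound 3 (0.89 log units; beyond the scatter).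

Compound 4 `O=S(=O)(NCCCNCc1ccc(Br)cc1)c1cc(C(F)(F)F)cc(C(F)(F)F)c1` differs from compound 3 by one change: bromo in place of hydrogen on an aromatic carbon. Among the compounds with values here, no measured pair shows this exact change. The nearest evidence is the step from compound 1 to compound 3, where removing two chlorines from the benzyl ring gave the rise noted above, and the step between compound 1 and compound 2, where an 8.3-fold higher number from compound 1 to compound 2 (0.92 log units; beyond the scatter). A ring carrying halogens thus went with a lower number than a bare or methoxy-bearing ring. A single bromo is a smaller change than two chlorines, so a smaller move in the same direction is expected.

The estimate for compound 4 is therefore 5000 nM, with a range from 2000 nM to 14000 nM, meaning an expected step of a 2.8-fold lower number from compound 3 to compound 4 (0.45 log units; beyond the scatter).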

Compound 4, concentration for 50% growth inhibition: 2000 nM
Compound 4: the middle estimate sits 2.5-fold (0.40 log units) above what was measured, and the stated range covers the measured number.
By their numbers in this assay, from the lowest: compounds 1 and 4 (each within the scatter of the next); then compounds 3 and 2 (each within the scatter of the next).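

In this assay, within the data shown here, the step of a 7.0-fold lower number from compound 3 to compound 4 (0.85 log units; beyond the scatter) is the first direct reading of a single change on the benzyl ring: one bromine atom replaces one hydrogen, and nothing else in the molecule differs. Compared with the 3,4-dimethoxyphenyl ring, the 4-bromophenyl ring gives a 7.5-fold lower number from compound 2 to compound 4 (0.88 log units; beyond the scatter), while compared with the 3,4-dichlorophenyl ring it gives a 1.1-fold higher number from compound 1 to compound 4 (0.05 log units; within the scatter), so one bromo at this position matches the two chlorines within the usual scatter of the measurement. No measurement shown here accounts for why this single atom moves growth inhibition so far.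

The compounds shown leave open whether this step is specific to bromo, or whether a single chloro, fluoro or methyl on the same ring carbon would produce a similar one, and whether a bromo on another carbon of the ring would match it. They also leave open whether the 4-bromobenzyl group would keep its effect with a longer chain joining the amine to the sulfonamide.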